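A Trifluoromethyl Swap on Compound 2

The compounds below may be only part of what the source reports. "The series", "measured", "known", "first", "only" and "open" are said of these compounds alone.

Compound 1 `COc1cc(C(=O)c2sc(-c3cccc([N+](=O)[O-])c3)cc2N)cc(OC)c1OC`: 7.5 nM
Compound 2 `COc1ccc(-c2cc(N)c(C(=O)c3cc(OC)c(OC)c(OC)c3)s2)cc1`: 18 nM

In a functional assay on MOLT-4 cells (Homo sapiens) for antiproliferative activity (on this read-out lower numbers stand for stronger inhibition and higher numbers for weaker inhibition), compound 2 holds the higher of the two numbers, at 18 nM, while compound 1 gives the lower, at 7.5 nM. The unmeasured compound 3 `COc1cc(C(=O)c2sc(-c3ccc(C(F)(F)F)cc3)cc2N)cc(OC)c1OC` keeps the core of compound 2 and has trifluoromethyl in place of methoxy on an aromatic carbon, para to a large group (trifluoromethyl in place of methoxy on an aromatic carbon). Among the measured compounds shown here, one measured step bears on this, a 2.4-fold higher number from compound 1 to compound 2 (0.38 log units; beyond the scatter), a modest change beyond the scatter that also involves the 4-methoxyphenyl group. For the measured compounds named here, no measured compound carries trifluoromethyl, so that step offers only a rough size and a tentative direction. A modest move to a lower number in this assay is therefore expected. The expected step is a 1.6-fold lower number from compound 2 to compound 3 (0.21 log units; within the scatter). For compound 3 the estimated value is 11 nM, with an expected range from 4 nM to 35 nM.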

Compound 3, half-maximal inhibitory concentration: 250 nM
The estimate for compound 3 lay 23-fold (1.36 log units) below the measured number; the whole stated range lies below it.
By their numbers in this assay, from the lowest: compound 1; then compound 2; then compound 3.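

In this assay, trifluoromethyl in place of methoxy on an aromatic carbon, para to a large group, gives a 14-fold higher number from compound 2 to compound 3 (1.14 log units; beyond the scatter) and is a large change, so this site proves far less forgiving than the modest 2.4-fold higher number from compound 1 to compound 2 (0.38 log units; beyond the scatter) had suggested. The 4-(trifluoromethyl)phenyl group in place of 3-nitrophenyl gives a 33-fold higher number from compound 1 to compound 3 (1.52 log units; beyond the scatter) and leaves compound 3 with the highest number of the three, showing that the choice of aryl group here can move the number much further than the earlier pair revealed. Nothing available explains the size of this loss.

The compounds shown leave open whether a methyl group, a chlorine atom or an amine in the same place would stay close to compound 2 or move towards compound 3. They also leave open whether the loss is specific to trifluoromethyl.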